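The source may hold more compounds than are shown below. What is called first, only, known or untested is meant among the compounds shown, and "the series" means these compounds.

Measured compounds:
Compound 1 `Cn1cncc1C(O)(c1ccc(C#N)cc1)c1cc2cc([N+](=O)[O-])cc(-c3ccccc3)c2o1` gives 1480 nM in a functional assay on QG-56 cells (Homo sapiens) for antiproliferative activity; on this read-out lower numbers stand for stronger inhibition and higher numbers for weaker inhibition.
Compound 2 `Cn1cncc1C(O)(c1ccc(C#N)cc1)c1cc2cc([N+](=O)[O-])cc(-c3cccc(C#N)c3)c2o1` gives 22.9 nM in this assay.
Compound 3 `COc1cccc(-c2cc([N+](=O)[O-])cc3cc(C(O)(c4ccc(C#N)cc4)c4cncn4C)oc23)c1` gives 38.8 nM in this assay.

Compound 1 stands highest of the three numbers in this assay; the nearest is compound 3, reached through a 38-fold lower number from compound 1 to compound 3 (1.58 log units; beyond the scatter), and the furthest compound 2, through a 65-fold lower number from compound 1 to compound 2 (1.81 log units; beyond the scatter). Between the other two lies a 1.7-fold higher number from compound 2 to compound 3 (0.23 log units; within the scatter). Compound 4 `Cn1cncc1C(O)(c1ccc(C(=O)O)cc1)c1cc2cc([N+](=O)[O-])cc(-c3ccccc3)c2o1` differs from compound 1 in one place: carboxy in place of cyano on an aromatic carbon. Both measured steps alter an aromatic carbon elsewhere on the shared core, so neither bears directly on this change. Going by the values given here, with no comparable step to lean on, the expectation rests on compound 1 alone and is wide: a step of a 1.7-fold higher number from compound 1 to compound 4 (0.23 log units; within the scatter) is expected, its direction uncertain. Compound 4 is estimated at 2500 nM in this assay, within 700 nM to 12000 nM.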

Compound 4, half-maximal inhibitory concentration: > 10000 nM
Compound 4 ended at the assay's limit; the forecaster's own chance of this, stated with the estimate: 10%; at least 4.0-fold (0.60 log units) between middle value and limit.
By their numbers in this assay, from the lowest: compounds 2 and 3 (each within the scatter of the next); then compound 1. At a limit, above all of these: compound 4.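

The earlier steps shown here altered another aromatic carbon on the shared core, whereas this change falls on the 4-cyanophenyl group, and in this assay carboxy in place of cyano gives an at least 6.7-fold higher number from compound 1 to compound 4 (0.82 log units; beyond the scatter). This position, para to a large group, is therefore not indifferent to what it carries. The reading for compound 4 is a limit of the assay and not a number, so the full size of the step stays unknown: the limit of > 10000 nM in this assay, at which 1 of the 4 values shown sits.

As far as these compounds go, whether a methyl ester, an amide or an amine here would stay closer to compound 1 remains open. So does whether carboxy would cost as much on compound 2 or compound 3.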